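The compounds below may be only part of what the source reports. "The series", "measured", "known", "first", "only" and "open" are said of these compounds alone.

The measured compounds:
Compound 1 `Cc1cc(NC(=O)Cn2nnc(-c3ccccc3)n2)n(C2CCCCC2)n1`: in an assay on HEK293 cells for activation of Kir3.1/Kir3.2 (Homo sapiens), read by thallium flux (on this read-out lower numbers stand for smaller maximal responses and higher numbers for larger maximal responses), compound 1 gives 92%.
Compound 2 `Cc1cc(NC(=O)Cn2nnc(-c3ccccc3)n2)n(C2CCOCC2)n1`: in this assay compound 2 gives 115%.
Compound 3 `CCC(C)n1nc(C)cc1NC(=O)Cn1nnc(-c2ccccc2)n1`: in this assay compound 3 gives only a limit, > 69%.

Compound 3 thus stands on a limit, not a number (the limit of > 69% in this assay, at which 1 of the 3 values shown sits), so the steps a step that the limit leaves unreadable from compound 1 to compound 3 and a step that the limit leaves unreadable from compound 2 to compound 3 cannot be sized. Compound 4 `Cc1cc(NC(=O)Cn2nnc(-c3ccccc3)n2)n(C2CCCC2)n1` differs from compound 3 by cyclopentyl in place of sec-butyl on an aromatic nitrogen. Within the data shown here, the only readable step on the same aromatic nitrogen is a number 23 percentage points higher from compound 1 to compound 2 (beyond the scatter), which swaps one ring for another; cyclopentyl resembles cyclohexyl, so compound 4 is expected to land near compound 1, consistent with the limit of compound 3. Compound 4 is expected to give 92%, between 72% and 112%. The step is estimated as a step that the limit leaves unreadable from compound 3 to compound 4, not readable beyond the limit.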

Compound 4, largest response reached (Emax), in percent of the reference or control that the assay uses: 105%
For compound 4 the middle estimate is 13 percentage points below the measured one; low and high end bracket the measured number.
By their numbers in this assay, from the lowest: compound 1; then compounds 4 and 2 (each within the scatter of the next).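

Cyclopentyl in place of cyclohexyl gives a number 13 percentage points higher from compound 1 to compound 4 (beyond the scatter) in this assay, so a change between carbon-only rings also moves the response at this aromatic nitrogen, which the oxan-4-yl step could not show. Cyclopentyl in place of oxan-4-yl gives a number 10 percentage points lower from compound 2 to compound 4 (within the scatter), so these two rings are not told apart here. The steps from compound 3 cannot be read, as its value is only a limit: the limit of > 69% in this assay, at which 1 of the 4 values shown sits.

From the compounds shown here alone, what a cyclobutyl ring or a piperidine ring would give on this aromatic nitrogen remains open. So does where sec-butyl stands relative to the ring groups.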